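Methyl to Difluoromethyl on the Triazole of Compound 1

The source may report more compounds than this note shows. Statements on the series, on what has been measured and on what is new or still open speak of the compounds shown alone.

The series is followed in a physicochemical assay for lipophilicity, measured as octanol-water partition, at pH 7.4; a lower number here means a more polar compound, a higher number a more lipophilic compound. Going by the values given here, compound 1, `Cc1n[nH]c(-c2nc(Cc3ccccc3F)c3ccccn23)n1`, gives 3.3, the highest of the three numbers measured so far. Compound 2, `Fc1ncncc1Cn1nc(-c2nc(C(F)(F)F)n[nH]2)c2cccnc21`, gives 3.2, a value within the scatter of compound 1. Compound 3, `Fc1ccccc1Cc1nc(-c2nc(C(F)(F)F)n[nH]2)n2cccnc12`, gives 2.5, which lies beyond the scatter below compound 1. Among the compounds with values here, the new compound 4, `Fc1ccccc1Cc1nc(-c2nc(C(F)F)n[nH]2)n2ccccc12`, keeps the shared core of compound 1 and alters only one group: difluoromethyl in place of methyl on an aromatic carbon. Within the data shown here, no measured pair shows this same change, so there is no reference step to lean on. For compound 4 the expected step is a number 0.20 log units higher from compound 1 to compound 4 (within the scatter), a small rise that may not clear the scatter. Compound 4 is estimated at 3.5, between 3.1 and 3.9.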

Compound 4, distribution coefficient: 3.8
Estimate against measurement, compound 4: 0.30 log units below, and the stated range covers the measured number.
By their numbers in this assay, from the lowest: compound 3; then compounds 2 and 1 (each within the scatter of the next); then compound 4.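

This pair alone isolates a change at this position, and in this assay difluoromethyl in place of methyl gives a number 0.50 log units higher from compound 1 to compound 4 (beyond the scatter), with the shared core held constant. The position is therefore not silent in this assay: the group on this aromatic carbon can move the number beyond the scatter. Nothing available explains the size or direction of this step.

On these data alone, with a single pair, it remains open whether the step would carry over to other cores. As far as these compounds go, how an amine or a hydroxymethyl group on this carbon would read also remains open.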